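Trimming the Acyl Group of the Weakest Compound

A few compounds are considered here, and "the series" means these few. Any claim that something is new, unique, unknown or untested is made for them only; others in the source may bear on it.

Compound 1, `N/C(=N\C(=O)CCc1c[nH]c2ccccc12)NCCCc1c[nH]cn1`: 398 nM
Compound 2, `CC(C)C(=O)/N=C(\N)NCCCc1c[nH]cn1`: 7760 nM
Compound 3, `N/C(=N\C(=O)CCCNC(=O)c1cc2ccccc2[nH]1)NCCCc1c[nH]cn1`: 741 nM

Of the compounds shown here, three with a shared core have been measured in a functional assay on ileum for antagonist activity at histamine H1 receptor (Cavia porcellus); on this read-out higher numbers stand for weaker binding and lower numbers for tighter binding. Compound 2 stands at the top of these numbers, that is, at the weak end: its value lies beyond the scatter above both compound 3 and compound 1, so among the three it is the weakest binder. Among the measured compounds shown here, compound 1 and compound 3 carry much larger groups on the carbonyl, but each differs from compound 2 in more than one place, so no single step between measured compounds can be read off.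

Compound 4, `CCC(=O)/N=C(\N)NCCCc1c[nH]cn1`, is the next compound to be measured. It differs from compound 2 by hydrogen in place of methyl on a saturated chain carbon bound to a carbonyl carbon and a saturated chain carbon; the same change, read one bond further out, turns isopropylcarbonyl into propanoyl. For the measured compounds named here, no measured pair shows what such a small trimming does on this core, so the expectation rests on the change being small. The step of a 1.2-fold higher number from compound 2 to compound 4 (0.06 log units; within the scatter) is expected to stay within the usual scatter, with a slight lean toward a higher number. For this assay compound 4 is estimated at 9000 nM, within a range of 4000 nM to 25000 nM.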

Compound 4, dissociation constant: 5130 nM
For compound 4 the middle estimate is 1.8-fold (0.24 log units) above the measured one, within the range that was stated.
By their numbers in this assay, from the lowest: compounds 1 and 3 (each within the scatter of the next); then compounds 4 and 2 (each within the scatter of the next).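

In this assay, putting hydrogen in place of methyl on the saturated chain carbon bound to a carbonyl carbon and a saturated chain carbon turns the isopropylcarbonyl group into propanoyl and gives a 1.5-fold lower number from compound 2 to compound 4 (0.18 log units; within the scatter), so the two compounds cannot be told apart. Among the compounds shown here, this is the first step on the shared core that can be read in one place, and it shows that at this position the methyl can go without the read-out leaving the usual scatter of repeated measurements. There is no independent information on why this swap leaves the two values within the scatter of each other.

Compound 1 and compound 3 each differ from compound 4 in more than one place, so the steps to them cannot be read, and what their much larger groups on the carbonyl contribute stays unsettled. Going by these compounds, it also stays open whether this position would tolerate something other than methyl or hydrogen just as well, for example a longer chain, an amine or a carboxylic acid.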